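The compounds below may be only part of what the source reports. "The series", "measured", "known", "first", "only" and "open" are said of these compounds alone.

Compound 1 `C[C@@H](O[C@H]1CN2C(=O)C=C(c3ccc[n+]([O-])c3)CC2[C@@H]1c1ccc(F)cc1)c1cc(C(F)(F)F)cc(C(F)(F)F)c1` in an assay on CHO cells for displacement of a labelled ligand from Substance-P receptor (Homo sapiens) (a higher number here means a weaker inhibitor, a lower number a stronger inhibitor), gives 0.15 nM. For the measured compounds named here, compound 2 `C[C@@H](O[C@H]1CN2C(=O)C=C(c3cnn(Cc4ccccc4)c3)CC2[C@@H]1c1ccc(F)cc1)c1cc(C(F)(F)F)cc(C(F)(F)F)c1` in this assay gives 1.9 nM, which is the higher of the two numbers so far; the step of a 13-fold higher number from compound 1 to compound 2 (1.10 log units; beyond the scatter) separates it from compound 1 and lies beyond the scatter. Compound 3 `CCc1noc(C2=CC(=O)N3C[C@H](O[C@H](C)c4cc(C(F)(F)F)cc(C(F)(F)F)c4)[C@@H](c4ccc(F)cc4)C3C2)n1` has not yet been measured. It differs from compound 2 in one place: 3-ethyl-1,2,4-oxadiazol-5-yl in place of 1-benzyl-1H-pyrazol-4-yl on a double-bonded ring carbon. Going by the values given here, the only measured step at this position is the one from compound 1 to compound 2, which was large and went upward when a single ring gave way to a two-ring group. Among the compounds with values here, compound 3 moves back to a single ring, though a different one from that of compound 1, and no measured pair shows how these two single rings compare. On this basis a moderate fall in the number is expected for compound 3 in this assay, a 3.2-fold lower number from compound 2 to compound 3 (0.50 log units; beyond the scatter), with the estimate for compound 3 placed at 0.6 nM and a range from 0.15 nM to 2.5 nM.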

Compound 3, half-maximal inhibitory concentration: 0.4 nM
Beside the measured number, compound 3's estimate is 1.5-fold (0.18 log units) above it, and the stated range covers the measured number.
By their numbers in this assay, from the lowest: compound 1; then compound 3; then compound 2.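

In this assay, replacing 1-benzyl-1H-pyrazol-4-yl with 3-ethyl-1,2,4-oxadiazol-5-yl on the double-bonded ring carbon brought a 4.8-fold lower number from compound 2 to compound 3 (0.68 log units; beyond the scatter), so a five-membered aromatic ring without a second ring attached can also give a low number at this position. The two groups of 7 heavy atoms still differ, with a 2.7-fold higher number from compound 1 to compound 3 (0.43 log units; beyond the scatter), so among these three compounds heavy-atom count alone does not set the number. Nothing measured here accounts for either step.

The compounds shown leave open how much of the higher number of compound 2 goes with its benzyl group, which a pyrazole carrying only a methyl group would test. They also leave open whether the ethyl group of compound 3 matters, compared with a methyl or a propyl chain at the same place.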